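The source may report more compounds than this note shows. Statements on the series, on what has been measured and on what is new or still open speak of the compounds shown alone.

Measured compounds in a functional assay on KYSE-510 cells (Homo sapiens) for antiproliferative activity, read by crystal violet staining, with a stated time of 96 h; a lower number here means a stronger inhibitor of growth, a higher number a weaker inhibitor of growth:
Compound 1 `Cc1ccc(S(=O)(=O)NC2=NCCN2C(=S)SN2CCn3c2nsc3=S)cc1` gives >= 20000 nM, which is a limit of the assay and not a number.
Compound 2 `Cc1cc(C)c(S(=O)(=O)NC2=NCCN2C(=S)SN2CCn3c2nsc3=S)c(C)c1` gives >= 20000 nM, again a limit of the assay.
Compound 3 `COc1ccc(S(=O)(=O)NC2=NCCN2C(=S)SN2CCn3c2nsc3=S)cc1OC` gives >= 20000 nM, also a limit of the assay.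

Compound 3 therefore stands only at a limit in this assay, and the two other values shown are limits as well (the limit of >= 20000 nM in this assay, at which 3 of the 3 values shown sit). The three steps among the measured compounds, a step that the two limits leave unreadable from compound 1 to compound 2, a step that the two limits leave unreadable from compound 1 to compound 3 and a step that the two limits leave unreadable from compound 2 to compound 3, cannot be read in size or direction because every end of them sits at the same limit (the limit of >= 20000 nM in this assay, at which 3 of the 3 values shown sit). Nothing in the measured set shows whether changing the aryl group on the sulfonyl sulfur moves growth inhibition at all.

Compound 4 `O=S(=O)(NC1=NCCN1C(=S)SN1CCn2c1nsc2=S)c1ccc(Br)cc1` differs from compound 3 by 4-bromophenyl in place of 3,4-dimethoxyphenyl on a sulfonyl sulfur. For the measured compounds named here, no measured step bears directly on this exchange, and the steps that do exist are unreadable. With three aryl variants all at the limit, the expected step is a step that the limit leaves unreadable from compound 3 to compound 4, that is, no readable change. Compound 4 is estimated at 25000 nM in this assay, with a range from 8000 nM to 60000 nM, and the result is most likely to be reported as a limit again.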

Compound 4, concentration for 50% growth inhibition: >= 20000 nM
Compound 4 was reported as a limit; the forecaster's own chance of this, stated with the estimate: 75%; the middle value lies beyond the limit too.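

Compound 4 sits at a limit of the assay, as do compound 1, compound 2 and compound 3, so none of the steps to compound 4 can be read in size or direction: the limit of >= 20000 nM in this assay, at which 4 of the 4 values shown sit. The compounds shown leave open whether any aryl group on the sulfonyl sulfur changes growth inhibition in this assay.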